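A few compounds are considered here, and "the series" means these few. Any claim that something is new, unique, unknown or untested is made for them only; others in the source may bear on it.

Compound 1 `COc1cc(NCc2ccc(C)s2)ccc1-c1cnco1` was tested in an ADME assay on Huh-7 cells (Homo sapiens) for cytotoxicity, read by MTT assay, with a stated time of 96 h (on this read-out higher numbers stand for lower toxicity in this test and lower numbers for higher toxicity in this test), and gives 34400 nM. Among the values shown in this assay this is the only number; the other entry is a limit. Compound 2 `COc1cc(/N=C/c2ccc(F)cc2)ccc1-c1cnco1` reaches > 100000 nM in this assay, which is a limit of the test and not a number; the limit of > 100000 nM in this assay, at which 1 of the 2 values shown sits, marks where that limit sits. Within the data shown here, compound 1 therefore stands as the single compound with a measured half-maximal cytotoxic concentration, and no step between measured compounds is on hand.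

Compound 3 `COc1cc(NCc2ccsc2)ccc1-c1cnco1` has not yet been measured in this assay. It differs from compound 1 in one place: thiophen-3-yl in place of 5-methylthiophen-2-yl on a saturated chain carbon bound to a nitrogen on an aromatic ring. A thiophen-3-yl replaces the 5-methylthiophen-2-yl on the saturated chain carbon bound to a nitrogen on the aromatic ring, while the shared core of compound 1 is kept.

Among the measured compounds shown here, with no measured step to lean on, the expected step from compound 1 to compound 3 is a modest move toward lower toxicity, close to the usual scatter, estimated as a 1.3-fold higher number from compound 1 to compound 3 (0.12 log units; within the scatter). Compound 3 is expected to give about 45000 nM in this assay, within a range from 17000 nM to 100000 nM.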

Compound 3, half-maximal cytotoxic concentration: 63100 nM
Compound 3: middle estimate off by 1.4-fold (0.15 log units), on the low side, and the stated range covers the measured number.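

Among these compounds, replacing the 5-methylthiophen-2-yl with a thiophen-3-yl on the saturated chain carbon bound to a nitrogen on an aromatic ring gives the first step that can be read in this assay: it is a 1.8-fold higher number from compound 1 to compound 3 (0.26 log units; within the scatter) and so does not separate the two compounds in this test. With the shared core kept, one substituted thiophene and one unsubstituted thiophene therefore read alike at this position, which a single measured compound could not show. The change, however, removes the methyl and alters the way the thiophene is attached in one move, so this step cannot assign anything to either part, and no measured property shown here bears on it.

The compounds shown leave open what a thiophen-2-yl without the methyl would give, a group that would separate the two parts of this change. They also leave open how this assay would read with a phenyl at this position, or with a thiophene carrying an amine or a carboxylic acid.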